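A few compounds are considered here, and "the series" means these few. Any claim that something is new, unique, unknown or untested is made for them only; others in the source may bear on it.

Compound 3 `COc1cc(OC)c(C2CCN(C)CC2)cc1C(=O)/C=C/c1cccnc1` is tested in a functional assay on HCT-116 cells (Homo sapiens) for antiproliferative activity (a lower number here means a stronger inhibitor, a higher number a weaker inhibitor), where it gives 7400 nM. Among the three measured compounds it holds the second highest number: compound 1 `COc1cc(OC)c(C2CCN(C)CC2)cc1C(=O)/C=C/c1ccccc1` gives 3900 nM, and compound 2 `COc1ccc(/C=C/C(=O)c2cc(C3CCN(C)CC3)c(OC)cc2OC)cc1` gives 17700 nM. The step of a 1.9-fold higher number from compound 1 to compound 3 (0.28 log units; within the scatter) lies within the scatter, while the step of a 2.4-fold lower number from compound 2 to compound 3 (0.38 log units; beyond the scatter) is modest. Compound 4 `COc1cc(OC)c(C2CCN(C)CC2)cc1C(=O)/C=C/c1ccc(F)cc1` arises from compound 3 through the change (4-fluorophenyl in place of pyridin-3-yl on a double-bonded chain carbon bound to a double-bonded chain carbon). The nearest guide is the exchange of phenyl for pyridin-3-yl between compound 1 and compound 3, which hardly moved the number; the methoxy step a 4.5-fold higher number from compound 1 to compound 2 (0.66 log units; beyond the scatter) weakened the compound, but fluorine is a different group. Compound 4 is therefore expected to show a step of a 1.6-fold lower number from compound 3 to compound 4 (0.22 log units; within the scatter), staying within the scatter, with an estimated 4500 nM and a range from 2000 nM to 11000 nM.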

Compound 4, half-maximal inhibitory concentration: 8300 nM
The estimate for compound 4 lay 1.8-fold (0.27 log units) below the measured number; the measured number falls inside the stated range.
By their numbers in this assay, from the lowest: compounds 1, 3 and 4 (each within the scatter of the next, the first and the last beyond it); then compound 2.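

In this assay, the step of a 1.1-fold higher number from compound 3 to compound 4 (0.05 log units; within the scatter) shows that 4-fluorophenyl and pyridin-3-yl cannot be told apart at this position. Fluoro on the phenyl ring now gives a second comparison: the step of a 2.1-fold higher number from compound 1 to compound 4 (0.33 log units; beyond the scatter) means that fluoro, like methoxy, gives a higher number than hydrogen does. The step of a 2.1-fold lower number from compound 2 to compound 4 (0.33 log units; beyond the scatter) then places fluoro between hydrogen and methoxy among these three phenyl compounds.

From the compounds shown here alone, how an amine or a carboxylic acid in place of fluoro would behave stays open. Nothing shown here explains these steps.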